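Nitro substitution on an inactive hydrazone-type cytotoxicity series

The compounds below may be only part of what the source reports. "The series", "measured", "known", "first", "only" and "open" are said of these compounds alone.

The series is examined in a functional assay on HepG2 cells (Homo sapiens) for cytotoxicity, read by sulforhodamine B assay, with a stated time of 72 h; on this read-out higher numbers stand for weaker inhibition and lower numbers for stronger inhibition. Compound 1 `Cc1c(-c2csc(/N=c3\sc(-c4ccccc4)nn3-c3ccccc3)n2)c(=O)n(-c2ccccc2)n1C` sits at the limit of this assay, giving > 100000 nM, which is a limit rather than a number. Compound 2 `CCOC(=O)c1nn(-c2ccccc2)/c(=N/c2nc(-c3c(C)n(C)n(-c4ccccc4)c3=O)cs2)s1` likewise reaches only the limit, with > 100000 nM in this assay. The step that the two limits leave unreadable from compound 1 to compound 2 therefore cannot be read, as both values sit at the limit of > 100000 nM in this assay, at which 2 of the 2 values shown sit. Compound 3 `CCOC(=O)c1nn(-c2ccc([N+](=O)[O-])cc2)/c(=N/c2nc(-c3c(C)n(C)n(-c4ccccc4)c3=O)cs2)s1` differs from compound 2 by nitro in place of hydrogen on an aromatic carbon. Within the data shown here, no measured step bears on this change, and the single measured step is itself unreadable, so no size or direction beyond the scatter can be foreseen for compound 3 in this assay. Compound 3 is estimated to stay at the same level, so the expected step of a number no higher from compound 2 to compound 3 (the limit leaves the size open) is none beyond the scatter. Compound 3 is thus expected to give 100000 nM, within a range of 30000 nM to 300000 nM, most likely again as a limit.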

Compound 3, half-maximal inhibitory concentration: 8110 nM
The estimate for compound 3 lay 12-fold (1.09 log units) above the measured number; the whole stated range lies above it.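

In this assay, among these compounds, the change from phenyl to 4-nitrophenyl gives an at least 12-fold lower number from compound 2 to compound 3 (1.09 log units; beyond the scatter) and so brings the series off its limit to a measured number for the first time, showing that this position on the ring can respond strongly to a single change. Compound 2 gives > 100000 nM as a limit and not a number, so the step fixes only a smallest size, and the read-out still rests largely on limits: the limit of > 100000 nM in this assay, at which 2 of the 3 values shown sit. Among the compounds shown here, the one earlier step cannot be read, so it gave no sign that any single change could move the read-out.

On these data alone, whether the gain belongs to the nitro group itself stays open, since an amine, a nitrile or a carboxylic acid at the same place might give a different number. As far as these compounds go, it also stays open whether 4-nitrophenyl has the same effect on compound 1, which carries phenyl in place of ethoxycarbonyl.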